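Swapping the Amine Arm for a Hydroxyl Arm

The source may report more compounds than this note shows. Statements on the series, on what has been measured and on what is new or still open speak of the compounds shown alone.

Of the compounds shown here, two have so far been tested in a functional assay on PC-6 cells (Homo sapiens) for antiproliferative activity; on this read-out lower numbers stand for stronger inhibition and higher numbers for weaker inhibition. Compound 1 `Cc1ccc(/C=N\Nc2ncnc3sc(C(C)(C)C)cc23)nc1` gives 0.009 ug/mL in this assay, while compound 2 `CN(C)Cc1cccc(/C=N\Nc2ncnc3sc(C(C)(C)C)cc23)n1` gives 0.381 ug/mL. Compound 2 therefore stands at the higher, weaker end of the two numbers, and its gap to compound 1 lies well beyond the scatter of repeated measurements. Compound 3 `CC(C)(C)c1cc2c(N/N=C\c3cccc(CO)n3)ncnc2s1` has not yet been tested. It differs from compound 2 in one place: hydroxy in place of dimethylamino on a saturated chain carbon bound to an aromatic carbon. Within the data shown here, no measured pair shows this exact exchange, so the size of the step cannot be read directly from earlier results. Still, compound 3 is expected to give a lower number than compound 2 because compound 1 gives 0.009 ug/mL with a methyl in place of the whole side chain. The expected step is a moderate fall, a 4.8-fold lower number from compound 2 to compound 3 (0.68 log units; beyond the scatter). Compound 3 is estimated at 0.08 ug/mL, within a range from 0.02 ug/mL to 0.4 ug/mL.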

Compound 3, half-maximal inhibitory concentration: 0.034 ug/mL
Compound 3: middle estimate off by 2.4-fold (0.37 log units), on the high side, and the stated range covers the measured number.
By their numbers in this assay, from the lowest: compound 1; then compound 3; then compound 2.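

Exchanging dimethylamino for hydroxy on a saturated chain carbon bound to an aromatic carbon gives an 11-fold lower number from compound 2 to compound 3 (1.05 log units; beyond the scatter) in this assay, so the group at the end of this arm strongly affects the read-out. The hydroxymethyl arm does not fully match the simple methyl compound: 6-(hydroxymethyl)pyridin-2-yl in place of 5-methylpyridin-2-yl gives a 3.8-fold higher number from compound 1 to compound 3 (0.58 log units; beyond the scatter), a modest step that still lies beyond the scatter. Nothing available explains either step.

Going by these compounds, it remains open whether the gain comes from the hydroxy itself or simply from the departure of dimethylamino, and a methoxy, a primary amine or a carboxylic acid on the same carbon could help separate these readings. A longer chain carrying the hydroxy would show whether the length of the arm also matters.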